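Swapping furan for thiophen on the shared core

This account rests on a few compounds, and the source may have more. Where it says the series, first, only, none or still open, it means among the compounds named here.

compound 1 `Clc1cccc(COC(CCn2cncn2)c2ccco2)c1`: 18600 nM
compound 2 `Clc1ccc(Cl)c(COC(CCn2cncn2)c2ccco2)c1`: 28900 nM

Among the measured compounds shown here, in an ADME assay on J774.A1 cells (Mus musculus) for cytotoxicity, read by MTT assay, with a stated time of 72 h (on this read-out lower numbers stand for higher toxicity in this test and higher numbers for lower toxicity in this test), compound 1 gives 18600 nM and compound 2 gives 28900 nM, so compound 1 stands within the scatter of its only measured neighbour.

Compound 3 `Clc1cccc(COC(CCn2cncn2)c2cccs2)c1`, still unmeasured, keeps the rest of compound 1 but carries thiophen-2-yl in place of furan-2-yl on a saturated chain carbon bound to an oxygen on a saturated carbon and a saturated chain carbon. For the measured compounds named here, no measured step covers this exchange. Going by the values given here, only one step exists, and it bears on the question only indirectly: a 1.6-fold higher number from compound 1 to compound 2 (0.19 log units; within the scatter), with chloro in place of hydrogen on an aromatic carbon, a change made elsewhere in the molecule. With that single step inside the scatter and compound 1 at 18600 nM as the starting point, no shift beyond the scatter is expected in this assay. The estimated step is a 1.1-fold higher number from compound 1 to compound 3 (0.03 log units; within the scatter). For compound 3 the expected value is 20000 nM, with an estimated range from 9000 nM to 45000 nM.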

Compound 3, half-maximal cytotoxic concentration: 15600 nM
The estimate for compound 3 lay 1.3-fold (0.11 log units) above the measured number; the measured number falls inside the stated range.
By their numbers in this assay, from the lowest: compounds 3, 1 and 2 (each within the scatter of the next).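

At the saturated chain carbon bound to an oxygen on a saturated carbon and a saturated chain carbon, thiophen-2-yl in place of furan-2-yl gives a 1.2-fold lower number from compound 1 to compound 3 (0.08 log units; within the scatter) in this assay, so this position now has a measured step of its own, which the earlier pair, changed elsewhere in the molecule, could not supply. The two groups match in heavy atoms, hydrogen-bond donors and hydrogen-bond acceptors, and the exchange of the ring oxygen for sulfur leaves the read-out within the scatter in this test. Nothing measured here explains this outcome.

The compounds shown leave open whether a phenyl ring, an amine or a carboxylic acid at this carbon would move the number beyond the scatter. They also leave open whether the chloro exchange, seen with furan-2-yl as a 1.6-fold higher number from compound 1 to compound 2 (0.19 log units; within the scatter), would give a similar step in a compound carrying thiophen-2-yl.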